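Sigma-1 binding across a small phenyl-dioxane amine series

A few compounds are considered here, and "the series" means these few. Any claim that something is new, unique, unknown or untested is made for them only; others in the source may bear on it.

Compounds measured:
compound 1 `C[C@@]1(c2ccccc2)OCC[C@@H](CCN)O1` — > 10000 nM
compound 2 `C[C@]1(c2ccccc2)OCC[C@H](CCNCc2ccccc2)O1` — 11 nM
compound 3 `CC[C@@]1(c2ccccc2)OCC[C@@H](CCNCc2ccccc2)O1` — 20 nM

In an assay on brain for displacement of a labelled ligand from Sigma non-opioid intracellular receptor 1 (Cavia porcellus) (a higher number here means a weaker inhibitor, a lower number a stronger inhibitor), compound 1 reaches only the assay limit, > 10000 nM, and not a number; this is the case noted in the limit of > 10000 nM in this assay, at which 1 of the 3 values shown sits. Compound 2 gives 11 nM in this assay. Compound 3 gives 20 nM, the highest of the two numbers shown, with compound 2 within the scatter of it.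

Compound 4 `C[C@@]1(c2ccccc2)OCC[C@@H](CCNCc2ccccc2)O1` is not yet measured. It differs from compound 3 by hydrogen in place of methyl on a saturated chain carbon bound to a saturated ring carbon. Among the compounds with values here, no measured pair spans this change, so the step is expected to stay within the scatter, in no fixed direction. For compound 4 the expected step of a 1.1-fold lower number from compound 3 to compound 4 (0.05 log units; within the scatter) is small, giving an estimate of 18 nM with a range from 6 nM to 60 nM.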

Compound 4, inhibition constant: 17 nM
The estimate for compound 4 lay 1.1-fold (0.02 log units) above the measured number, and the stated range covers the measured number.
By their numbers in this assay, from the lowest: compounds 2, 4 and 3 (each within the scatter of the next). At a limit, above all of these: compound 1.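

In this assay, the change from ethyl to methyl at this place is small: a 1.2-fold lower number from compound 3 to compound 4 (0.07 log units; within the scatter). Inverting all stereocentres also stays within the scatter, a 1.5-fold higher number from compound 2 to compound 4 (0.19 log units; within the scatter), a reading that rests on: the fact that compounds 2 and 4 differ only in the configuration as drawn. Benzyl on the amine nitrogen is the one large change among these steps, an at least 580-fold lower number from compound 1 to compound 4 (2.76 log units; beyond the scatter), and its compound 1 end is a limit of the assay and not a number: the limit of > 10000 nM in this assay, at which 1 of the 4 values shown sits.

Open, going by these compounds, is how a propyl or a cyclohexyl group in this place would read. Also open, on these data alone, is how a phenethyl group on the amine nitrogen would compare with benzyl.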